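Amine swap on the aniline of compound 1

This account rests on a few compounds, and the source may have more. Where it says the series, first, only, none or still open, it means among the compounds named here.

compound 1, `CCCN(CCC)c1ccc(Nc2ncc(Cl)c(Oc3cccc(NC(=O)CC)c3)n2)cc1`: "not active" (no number reported)
compound 2, `CCC(=O)Nc1cccc(Oc2nc(Nc3ccc(N(C)C)cc3OC)ncc2Cl)c1`: 15%
compound 3, `CCC(=O)Nc1cccc(Oc2nc(Nc3ccc(N4CCCC4)cc3OC)ncc2Cl)c1`: "not active" (no number reported)

In an assay on isolated protein for inhibition of NUAK family SNF1-like kinase 2 (Homo sapiens), read by ADP-Glo, with a stated time of 60 min, tested at 10 uM, in the presence of a further agent that is not named here (a lower number here means less inhibition, a higher number more inhibition at the concentration tested (going by the name of the read-out)), compound 1 gives "not active" (no number reported), so no number stands for it; compound 3 is likewise without a number, and only compound 2 gives 15%. Compound 1 therefore stands without a figure to set against the others. Compound 4 is `CCC(=O)Nc1cccc(Oc2nc(Nc3ccc(N4CCCCC4)cc3)ncc2Cl)c1`; relative to compound 1 the change is piperidin-1-yl in place of dipropylamino on an aromatic carbon. Within the data shown here, no measured pair shows this change, so the expected step in this assay is none beyond the scatter, in either direction, with a fair chance that compound 4 is again reported without a number. Compound 4 is expected to give about 8%, within 0% to 25%.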

Compound 4, a percentage reported as inhibition, at one concentration (the size of the read-out at that concentration, not a potency): 72.3%
Beside the measured number, compound 4's estimate is 64.3 percentage points below it; the whole stated range lies below it.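

Among these compounds, compound 1 carries no number, so no step from it to compound 4 can be read. No available evidence bears on this result. The compounds shown leave open how much of the reading for compound 4 belongs to piperidin-1-yl itself.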